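From Fluoro to Methyl on a Shared Core

This account rests on a few compounds, and the source may have more. Where it says the series, first, only, none or still open, it means among the compounds named here.

Of the compounds shown here, three have numbers so far in a physicochemical assay for lipophilicity (on this read-out lower numbers stand for lower lipophilicity and higher numbers for higher lipophilicity), and they lie far apart. Compound 2 (`COc1c(OC)c(OC(C)=O)c2cc(F)ccc2c1OC(C)=O`) is the lowest of them (2.75) and stands beyond the scatter from both others. Compound 1 (`COc1c(OC)c(OC(=O)C(C)(C)C)c2ccccc2c1OC(=O)C(C)(C)C`) comes nearest to it (5.69), while compound 3 (`CC(C)Oc1c(OC(C)C)c(OC(=O)C(C)(C)C)c2cc(Cl)ccc2c1OC(=O)C(C)(C)C`) lies furthest away (7.9).

Compound 4 (`COc1c(OC)c(OC(C)=O)c2cc(C)ccc2c1OC(C)=O`) has not yet been measured. It differs from compound 2 in one place, with methyl in place of fluoro on an aromatic carbon. Among the compounds with values here, no two measured compounds differ in one place only, so the data hold no direct measure of this exchange. Compound 1 and compound 3 each differ from compound 2 in more than one place, and their gaps to it cannot simply be carried over.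

What is expected in this assay is a small rise close to the scatter, much smaller than the gap between compound 2 (2.75) and compound 1 (5.69). The expected change is a number 0.35 log units higher from compound 2 to compound 4 (beyond the scatter) and it remains an estimate until a measurement exists. Compound 4 is thus estimated at 3.1 (expected range 2.75 to 3.5).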

Compound 4, partition coefficient: 2.86
Beside the measured number, compound 4's estimate is 0.24 log units above it; the measured number falls inside the stated range.
By their numbers in this assay, from the lowest: compounds 2 and 4 (each within the scatter of the next); then compound 1; then compound 3.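

Within the data shown here, compound 4 gives the study its first pair of compounds that differ in one place, and with it the first direct reading in this assay of methyl in place of fluoro on an aromatic carbon: the step is a number 0.11 log units higher from compound 2 to compound 4 (within the scatter), so on this read-out the two groups cannot be told apart at this place on the shared core, meta to a fused ring and para to a fused ring. The earlier compounds shown here could not show this, as compound 1 and compound 3 each differ from compound 2 in more than one place and their wide gaps say nothing about this exchange taken alone. Nothing on hand explains why the two numbers lie so close.

The compounds shown leave open whether a larger change at this place, such as an amine or a carboxylic acid, would also stay within the scatter of compound 2, as fluoro and methyl are the only two groups compared directly here. They also leave open whether methyl in place of fluoro would read the same on the core of compound 1, which carries different groups elsewhere.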